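This account rests on a few compounds, and the source may have more. Where it says the series, first, only, none or still open, it means among the compounds named here.

Of the compounds shown here, two built on one shared core have been tested in a functional assay on UACC-62 cells (Homo sapiens) for antiproliferative activity, read by sulforhodamine B assay, with a stated time of 48 h; a lower number here means a stronger inhibitor, a higher number a weaker inhibitor. Compound 1 `COc1cc(-c2nn(-c3ccc(NC(=O)c4cc(Cl)cc(Cl)c4)cc3)cc2-c2ccncc2)ccc1Cl` gives 4580 nM in this assay, the higher of the two numbers. Within the data shown here, compound 2 `COc1cc(-c2nn(-c3ccc(NC(=O)c4ccc(Cl)c(C(F)(F)F)c4)cc3)cc2-c2ccncc2)ccc1Cl` gives 2180 nM in this assay; the single measured step, a 2.1-fold lower number from compound 1 to compound 2 (0.32 log units; beyond the scatter), concerns only the group on the carbonyl carbon. Compound 3 `O=C(Nc1ccc(-n2cc(-c3ccncc3)c(-c3ccc(Cl)c(O)c3)n2)cc1)c1cc(Cl)cc(Cl)c1` has not yet been measured. It differs from compound 1 in one place: hydrogen in place of methyl on an oxygen on an aromatic ring. Among the measured compounds shown here, no measured step touches this part of the structure; the change from compound 1 to compound 2 sits on the carbonyl carbon and says nothing about the oxygen on the aromatic ring. With nothing pointing either way, the step of a 1.0-fold lower number from compound 1 to compound 3 (0.01 log units; within the scatter) is expected to stay within the usual scatter. Compound 3 is therefore estimated at 4500 nM in this assay, with a range of 1500 nM to 14000 nM.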

Compound 3, half-maximal inhibitory concentration: 2730 nM
Beside the measured number, compound 3's estimate is 1.6-fold (0.22 log units) above it; the range from low to high includes it.
By their numbers in this assay, from the lowest: compounds 2, 3 and 1 (each within the scatter of the next, the first and the last beyond it).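

In this assay, among these compounds, trading methoxy for hydroxy on the 4-chloro-3-methoxyphenyl group gives a 1.7-fold lower number from compound 1 to compound 3 (0.22 log units; within the scatter), the first reading at this position. The methyl on the oxygen can therefore be removed without a shift that stands clear of the scatter, at least in this one pair, so a free hydroxy is tolerated here alongside the 3,5-dichlorophenyl amide. No measurement at hand offers an explanation for this result.

Among the compounds shown here, whether the same swap would hold up with the 4-chloro-3-(trifluoromethyl)phenyl group of compound 2 remains open, since no pair with that group covers this position. Also open, from the compounds shown here alone, is how other groups on this oxygen, such as an ethyl or a longer chain, or an amine in place of the oxygen, would read in this assay.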